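The source may report more compounds than this note shows. Statements on the series, on what has been measured and on what is new or still open speak of the compounds shown alone.

Measured in a functional assay on MOLT-4 cells (Homo sapiens) for antiproliferative activity, read by MTT assay, with a stated time of 48 h; on this read-out lower numbers stand for stronger inhibition and higher numbers for weaker inhibition:
- compound 1 `O=C(/C=C/c1ccc(Cn2cc(Nc3ncc(Cl)c(Nc4ccc(F)cc4)n3)cn2)cc1)NO`: 330 nM
- compound 2 `O=C(CCCCCn1cc(Nc2ncc(Cl)c(Nc3cccc(Cl)c3)n2)cn1)NO`: 80 nM
- compound 3 `CNc1nc(Nc2cnn(CCCCCCC(=O)NO)c2)ncc1Cl`: 110 nM

Among these three, compound 3 at 110 nM lies within the scatter of compound 2. Its number is lower than that of compound 1, and that gap is beyond the scatter.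

The next compound, compound 4 `O=C(CCCCCCn1cc(Nc2ncc(Cl)c(Nc3ccccc3Cl)n2)cn1)NO`, has not yet been measured. It replaces methyl with 2-chlorophenyl on a nitrogen on an aromatic ring (2-chlorophenyl in place of methyl on a nitrogen on an aromatic ring).

Among the compounds with values here, no measured pair differs in one place only, so the effect of this change in this assay has not been seen directly. Compound 1 and compound 2 also carry a six-membered aromatic ring of carbon only on that nitrogen. Even so, the two differ elsewhere, and compound 1 gives 330 nM while compound 2 gives 80 nM. The values therefore allow only a loose expectation: no step beyond the scatter, with any shift more likely towards a lower number. The expected change is a 1.5-fold lower number from compound 3 to compound 4 (0.17 log units; within the scatter), an estimate that remains uncertain. The estimated value for compound 4 is 75 nM, with an expected range from 25 nM to 230 nM.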

Compound 4, half-maximal inhibitory concentration: 510 nM
Compound 4: the middle estimate sits 6.8-fold (0.83 log units) below what was measured, and the stated range ends below it.
By their numbers in this assay, from the lowest: compounds 2 and 3 (each within the scatter of the next); then compounds 1 and 4 (each within the scatter of the next).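

In this assay, placing 2-chlorophenyl in place of methyl on a nitrogen on an aromatic ring gives a 4.6-fold higher number from compound 3 to compound 4 (0.67 log units; beyond the scatter), a step towards weaker inhibition. Within the data shown here, this is the first direct reading of the change, as the earlier compounds that carry an aromatic ring on that nitrogen also differ elsewhere and so could not isolate its effect. It shows that, for this pair, the position is not indifferent to what it carries: with the rest of the structure unchanged, exchanging the single carbon of methyl for the seven heavy atoms of 2-chlorophenyl goes with a loss of activity beyond the scatter, and nothing given here accounts for that loss.

The compounds shown leave open whether the step belongs to the aromatic ring itself or to its chlorine, a question that a plain phenyl on that nitrogen would address, while an ethyl or a cyclopropyl would show how much change the position allows before activity falls. Also open, from the compounds shown here alone, is whether the step would keep its size on a different chain, or with a ring such as a piperidine on that nitrogen.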